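Replacing a hydroxylated aryl with 2,6-dichlorophenyl

This account rests on a few compounds, and the source may have more. Where it says the series, first, only, none or still open, it means among the compounds named here.

- compound 1, `CN(C)CCn1cnnc1-c1cc(Oc2ccc(NC(=O)N/N=C/c3ccc(F)cc3Cl)cc2F)ccn1`; in a functional assay on U-87MG ATCC cells (Homo sapiens) for cytotoxicity, read by MTT assay, with a stated time of 72 h (on this read-out higher numbers stand for weaker inhibition and lower numbers for stronger inhibition), compound 1 gives 1210 nM
- compound 2, `CN(C)CCn1cnnc1-c1cc(Oc2ccc(NC(=O)N/N=C/c3ccc(O)c(O)c3)cc2F)ccn1`; in this assay compound 2 reports only the assay's limit, > 100000 nM
- compound 3, `CN(C)CCn1cnnc1-c1cc(Oc2ccc(NC(=O)N/N=C/c3cc(Br)c(O)c(Br)c3)cc2F)ccn1`; in this assay compound 3 also reports only a limit, > 100000 nM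
- compound 4, `CN(C)CCn1cnnc1-c1cc(Oc2ccc(NC(=O)N/N=C/c3c(Cl)cccc3Cl)cc2F)ccn1`, not yet measured

Within the data shown here, compound 3 thus stands at the limit of this assay, sharing that position with compound 2 (the limit of > 100000 nM in this assay, at which 2 of the 3 values shown sit); compound 1 is the only member with a read number. The move to compound 4 is 2,6-dichlorophenyl in place of 3,5-dibromo-4-hydroxyphenyl on a carbon with a double bond to nitrogen. Among the measured compounds shown here, two measured steps bear on it, each running the opposite way, from a ring carrying only halogens to one carrying hydroxyl: an at least 82-fold higher number from compound 1 to compound 3 (1.91 log units; beyond the scatter) and an at least 82-fold higher number from compound 1 to compound 2 (1.91 log units; beyond the scatter). The step that the two limits leave unreadable from compound 2 to compound 3 gives no usable size. Compound 4 carries only chlorines on that ring, and compound 1 with only halogens gives 1210 nM, so a large downward step is expected, an at least 40-fold lower number from compound 3 to compound 4 (1.60 log units; beyond the scatter). Compound 4 is expected to give 2500 nM, with a likely range from 700 nM to 15000 nM.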

Compound 4, half-maximal inhibitory concentration: > 100000 nM
Compound 4 ended at the assay's limit; the forecaster's own chance of this, stated with the estimate: 15%; middle value at least 40-fold (1.60 log units) away from the limit.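

In this assay, a ring carrying only halogens does not by itself give a readable value at this position: 2,6-dichlorophenyl in place of 2-chloro-4-fluorophenyl on a carbon with a double bond to nitrogen gives an at least 82-fold higher number from compound 1 to compound 4 (1.91 log units; beyond the scatter). Among the earlier compounds, hydroxyl appeared on the ring in both compounds at the limit, but compound 4 has no hydroxyl there, so that group no longer separates compound 1 from the others. The steps among compound 2, compound 3 and compound 4 cannot be read, and compound 1 remains the only one with a read number: the limit of > 100000 nM in this assay, at which 3 of the 4 values shown sit.

Which part of the 2-chloro-4-fluorophenyl group matters remains open, and the simpler 2-chlorophenyl and 4-fluorophenyl groups would address that. Going by these compounds, how a methoxy group or an amine on this ring would read is also open.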